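Swapping sulfamoyl for ethoxycarbonyl on a shared core

The source may report more compounds than this note shows. Statements on the series, on what has been measured and on what is new or still open speak of the compounds shown alone.

Measured so far:
- compound 1, `CN(C)CCCOc1ccc(Nc2nccc(-c3cccnc3)n2)cc1`: 600 nM
- compound 2, `c1cncc(-c2ccnc(Nc3ccc(-n4ccnc4)cc3)n2)c1`: 1300 nM
- compound 3, `NS(=O)(=O)c1ccc(Nc2nccc(-c3cccnc3)n2)cc1`: 200 nM

In a functional assay for inhibition, with Homo sapiens as the target (on this read-out higher numbers stand for weaker inhibition and lower numbers for stronger inhibition), compound 3 gives the lowest of the three numbers. The nearest of the others is compound 1, and the step of a 3.0-fold lower number from compound 1 to compound 3 (0.48 log units; beyond the scatter) lies beyond the scatter. The furthest is compound 2, and the step of a 6.5-fold lower number from compound 2 to compound 3 (0.81 log units; beyond the scatter) is also beyond the scatter. Compound 3 is therefore the strongest inhibitor of the three on this read-out.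

Compound 4, `CCOC(=O)c1ccc(Nc2nccc(-c3cccnc3)n2)cc1`, has not yet been measured. It differs from compound 3 in one place: ethoxycarbonyl in place of sulfamoyl on an aromatic carbon. Both measured steps that end at compound 3 bear on this change, since each of them also swapped the group on that aromatic carbon while keeping the rest of the core untouched. In both, arriving at sulfamoyl gave a lower number; leaving it again in compound 4 is therefore expected to give a higher one, with the size uncertain because neither a 3.0-fold lower number from compound 1 to compound 3 (0.48 log units; beyond the scatter) nor a 6.5-fold lower number from compound 2 to compound 3 (0.81 log units; beyond the scatter) involved ethoxycarbonyl itself. For compound 4 a modest rise, a 3.5-fold higher number from compound 3 to compound 4 (0.54 log units; beyond the scatter), is expected. The estimated value for compound 4 in this assay is 700 nM, with a range from 250 nM to 2000 nM.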

Compound 4, half-maximal inhibitory concentration: 12400 nM
Compound 4: the middle estimate sits 18-fold (1.25 log units) below what was measured, outside the stated range (above it).
By their numbers in this assay, from the lowest: compound 3; then compound 1; then compound 2; then compound 4.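

In this assay this aromatic carbon, para to a large group, proves far more sensitive to the choice of group than the first three compounds showed, since ethoxycarbonyl in place of sulfamoyl gives a 62-fold higher number from compound 3 to compound 4 (1.79 log units; beyond the scatter) and that step is larger than any step among those three. Ethoxycarbonyl also compares poorly with the other two groups, with a 21-fold higher number from compound 1 to compound 4 (1.32 log units; beyond the scatter) and a 9.5-fold higher number from compound 2 to compound 4 (0.98 log units; beyond the scatter) as the steps, which makes compound 4 the weakest inhibitor of the four. The computed counts show that the 1 hydrogen-bond donor of sulfamoyl gives way to 0 in ethoxycarbonyl while hydrogen-bond acceptors stay at 2, but no measurement at hand says whether this difference has anything to do with the result.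

The compounds shown leave open whether a carboxamide or a carboxylic acid on the same aromatic carbon would fall nearer to compound 3 or to compound 4. They also leave open how much the ethyl part of the ethoxycarbonyl group contributes, a question that methoxycarbonyl at this place would address.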